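Cytotoxicity step from acetyl to cyclohexylcarbonyl

This account rests on a few compounds, and the source may have more. Where it says the series, first, only, none or still open, it means among the compounds named here.

Compound 2 `CC(=O)N1CCN(c2cc(NCCN)c3ccccc3n2)CC1` is the nearest measured neighbour of the new compound. In an ADME assay on HEp-2 cells (Homo sapiens) for cytotoxicity, read by CCK-8 assay, with a stated time of 6 days (a lower number here means that less compound is tolerated, a higher number that more compound is tolerated), compound 2 gives > 100000 nM, which is a limit of the assay and not a number. Compound 1 `NCCNc1cc(N2CCN(c3ccccc3Cl)CC2)nc2ccccc12` gives 20800 nM in this assay. The one measured step reads an at least 4.8-fold higher number from compound 1 to compound 2 (0.68 log units; beyond the scatter), so compound 2 stands at the top of the numbers shown, as the limit of > 100000 nM in this assay, at which 1 of the 2 values shown sits, records. Compound 3 `NCCNc1cc(N2CCN(C(=O)C3CCCCC3)CC2)nc2ccccc12` differs from compound 2 by cyclohexyl in place of methyl on a carbonyl carbon. Among the measured compounds shown here, no measured step touches the group on the carbonyl carbon, so the measured step bears on the new one only indirectly, by placing compound 2 at a limit. A move of compound 3 back toward a finite number is expected, so a modest step of an at least 1.6-fold lower number from compound 2 to compound 3 (0.22 log units; that floor lies within the scatter) downward is the working expectation. Compound 3 is therefore estimated at 60000 nM, in the range 15000 nM to 150000 nM.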

Compound 3, half-maximal cytotoxic concentration: > 100000 nM
Compound 3: a limit, no number; the forecaster's own chance of this, stated with the estimate: 40%; middle value at least 1.6-fold (0.22 log units) from the limit.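

In this assay compound 3 gives > 100000 nM, which is a limit of the assay and not a number. The measured step is an at least 4.8-fold higher number from compound 1 to compound 3 (0.68 log units; beyond the scatter), so a six-membered ring of carbon only on the carbonyl carbon does not by itself bring back a finite number. The step between compound 2 and compound 3 cannot be read, and the series now rests mostly on the ceiling: the limit of > 100000 nM in this assay, at which 2 of the 3 values shown sit.

From the compounds shown here alone, how compound 2 and compound 3 truly stand relative to each other stays open. Also open, going by these compounds, is whether an amine, a carboxylic acid or a phenyl in place of cyclohexyl on a carbonyl carbon would give a finite number in this assay.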